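The source may hold more compounds than are shown below. What is called first, only, known or untested is meant among the compounds shown, and "the series" means these compounds.

Measured in a functional assay on ACHN cells (Homo sapiens) for cytotoxicity; on this read-out higher numbers stand for weaker inhibition and lower numbers for stronger inhibition:
compound 1, `CO/N=c1\[nH]cnc2c1[n+](C/C=C(\C)CCCC(C)CCCC(C)CCCC(C)C)cn2C`, 16900 nM
compound 2, `C/C(=C\C[n+]1cn(C)c2nc[nH]/c(=N\OCc3ccccc3)c21)CCCC(C)CCCC(C)CCCC(C)C`, 20500 nM
compound 3, `CO/N=c1\[nH]cnc2ncn(C/C=C(\C)CC/C=C(\C)CC/C=C(\C)CCC=C(C)C)c12`, 18100 nM

The three numbers lie close together. Among the compounds with values here, the single measured one-point change is phenyl in place of hydrogen on a saturated chain carbon bound to an oxygen, which gave a 1.2-fold higher number from compound 1 to compound 2 (0.08 log units; within the scatter). The difference between the core of compound 1 and the core of compound 3 is not broken down here. Compound 4, `CC(C)=CCC/C(C)=C/CC/C(C)=C/CC/C(C)=C/Cn1cnc2nc[nH]/c(=N\OCc3ccccc3)c21`, is not yet measured; it differs from compound 3 by phenyl in place of hydrogen on a saturated chain carbon bound to an oxygen, the same change as between compound 1 and compound 2, at the same place. In this assay compound 4 is expected to shift by a 1.2-fold higher number from compound 3 to compound 4 (0.06 log units; within the scatter), resting on the step already seen, a 1.2-fold higher number from compound 1 to compound 2 (0.08 log units; within the scatter), which stayed within the scatter. The estimate for compound 4 is 21000 nM, with a likely range from 12000 nM to 38000 nM.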

Compound 4, half-maximal inhibitory concentration: 27400 nM
Beside the measured number, compound 4's estimate is 1.3-fold (0.12 log units) below it; the measured number falls inside the stated range.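

The same change, methoxy to benzyloxy, on the core of compound 3 in this assay gave a small step (a 1.5-fold higher number from compound 3 to compound 4 (0.18 log units; within the scatter)). Set beside the earlier step, it does not differ: the same change on two cores in this assay, a 1.2-fold higher number (0.08 log units; within the scatter) from compound 1 to compound 2 and a 1.5-fold higher number (0.18 log units; within the scatter) from compound 3 to compound 4, 1.2-fold (0.10 log units) apart, within the scatter of two such steps. The change therefore carries between these two cores at this one place with no step beyond the scatter, but this does not show that phenyl has a real effect on either core, and two such steps fix no size for it.

Still open, from the compounds shown here alone, is whether an amine or a carboxylic acid on the phenyl, or a longer chain in place of benzyl, would move the number beyond the scatter on either core.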